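Same Fluorinated Swap, Two Different Places on the Ring

The source may report more compounds than this note shows. Statements on the series, on what has been measured and on what is new or still open speak of the compounds shown alone.

The four compounds here share one core and differ in a fluorinated group on a benzene ring. Compound 1 `CC(C)(NC(=O)c1ccc([N+](=O)[O-])o1)c1ccc(OC(F)(F)F)cc1` and compound 2 `CC(C)(NC(=O)c1ccc([N+](=O)[O-])o1)c1ccc(C(F)(F)F)cc1` differ in a single place: trifluoromethyl in place of trifluoromethoxy on an aromatic carbon. In an ADME assay on Vero cells (Chlorocebus sabaeus) for cytotoxicity, read by MTT assay, with a stated time of 48 h (a lower number here means that less compound is tolerated, a higher number that more compound is tolerated), compound 1 gives 70000 nM. Compound 2 reaches only a limit of the assay, > 150000 nM. The step is an at least 2.1-fold higher number from compound 1 to compound 2 (0.33 log units; beyond the scatter), and it can only be given as a minimum because of the limit of > 150000 nM in this assay, at which 1 of the 3 values shown sits. Compound 3 `CC(C)(NC(=O)c1ccc([N+](=O)[O-])o1)c1ccc(COc2ccccc2OC(F)(F)F)cc1` gives 13000 nM; the difference between its core and the core of compound 1 is not broken down here. Compound 4 `CC(C)(NC(=O)c1ccc([N+](=O)[O-])o1)c1ccc(COc2ccccc2C(F)(F)F)cc1` carries the same kind of change, (trifluoromethyl in place of trifluoromethoxy on an aromatic carbon), but the place differs: ortho to a large group rather than para to a large group. Compound 4 is expected to shift by a 1.9-fold higher number from compound 3 to compound 4 (0.28 log units; within the scatter), resting on the size of an at least 2.1-fold higher number from compound 1 to compound 2 (0.33 log units; beyond the scatter). The estimate for compound 4 is 25000 nM, expected to lie between 10000 nM and 60000 nM.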

Compound 4, half-maximal cytotoxic concentration: 14000 nM
The estimate for compound 4 lay 1.8-fold (0.25 log units) above the measured number, and the stated range covers the measured number.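

Where the group sits ortho to a large group, trifluoromethyl in place of trifluoromethoxy gives a 1.1-fold higher number from compound 3 to compound 4 (0.03 log units; within the scatter) in this assay, so no difference can be read at that place. Set beside the earlier step, this result neither shows that the change carries over from one core to the other nor shows that it fails to: the same change on two cores in this assay, an at least 2.1-fold higher number (0.33 log units; beyond the scatter) from compound 1 to compound 2 and a 1.1-fold higher number (0.03 log units; within the scatter) from compound 3 to compound 4; the limit leaves it open whether they differ

Compound 2 stands at a limit of the assay, > 150000 nM, and not at a number.

From the compounds shown here alone, whether a methyl group or a nitrile on the same aromatic carbon would read like either fluorinated group stays open. So does whether the change behaves the same way on any further core.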